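A few compounds are considered here, and "the series" means these few. Any claim that something is new, unique, unknown or untested is made for them only; others in the source may bear on it.

Measured in a functional assay on HepG2 cells (Homo sapiens) for cytotoxicity, read by MTT assay; a lower number here means a stronger inhibitor, a higher number a weaker inhibitor:
compound 1 `COc1ccc(/C=C/C(=O)c2ccc(OC)c3c2OC(C)(C)C=C3)cc1OCCO`: > 10000 nM, a limit of the assay
compound 2 `COc1ccc(/C=C/C(=O)c2ccc(OC)c3c2OC(C)(C)C=C3)cc1OC(=O)CCl`: 120 nM

Going by the values given here, compound 2 holds the only true number so far. The other entry is the limit of > 10000 nM in this assay, at which 1 of the 2 values shown sits, for compound 1.

The next analogue is compound 3 `COc1cccc(C(=O)Oc2cc(/C=C/C(=O)c3ccc(OC)c4c3OC(C)(C)C=C4)ccc2OC)c1`. It keeps the shared core and the carbonyl of compound 2, with 3-methoxyphenyl in place of chloromethyl on a carbonyl carbon.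

Among the compounds with values here, only one measured step bears on this change: an at least 83-fold lower number from compound 1 to compound 2 (1.92 log units; beyond the scatter). That exchange differs from the present one, but it sits on the same oxygen and shows that the group there can move the number strongly. The data do not separate the part played by the carbonyl from that of the chloromethyl, so the size of the next step is poorly constrained.

A sizeable move toward a higher number in this assay is expected, and the estimated step is a 13-fold higher number from compound 2 to compound 3 (1.10 log units; beyond the scatter). Compound 3 is estimated at 1500 nM, with an expected range from 250 nM to 10000 nM.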

Compound 3, half-maximal inhibitory concentration: 870 nM
Compound 3: the middle estimate sits 1.7-fold (0.24 log units) above what was measured; low and high end bracket the measured number.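

In this assay, going by these compounds alone, exchanging the group on the carbonyl carbon gives a 7.3-fold higher number from compound 2 to compound 3 (0.86 log units; beyond the scatter), so the group held by the carbonyl moves the number by itself, a contribution that the single earlier step could not separate from that of the carbonyl. The exchange of 2-hydroxyethyl on the same oxygen for (3-methoxyphenyl)carbonyl still gives an at least 11-fold lower number from compound 1 to compound 3 (1.06 log units; beyond the scatter), so among the compounds shown, a lower number than that of compound 1 does not depend on chloromethyl, and a group with one six-membered aromatic ring is accepted on this carbonyl carbon. This comparison gives a bound and not an exact size, as compound 1 stands at a limit of the assay: the limit of > 10000 nM in this assay, at which 1 of the 3 values shown sits.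

The step from chloromethyl to 3-methoxyphenyl changes the chlorine, the ring and the methoxy oxygen at once, so the compounds shown cannot assign the difference to any one of them. On these data alone, how a plain methyl or an unsubstituted phenyl on the carbonyl carbon would read remains open, as does whether an amide nitrogen in place of the oxygen on the aromatic ring would keep the number of compound 2 or compound 3.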